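The source may report more compounds than this note shows. Statements on the series, on what has been measured and on what is new or still open speak of the compounds shown alone.

Measured so far:
Compound 1, `Cc1cc(-c2ccccn2)cc(C(=O)NNS(=O)(=O)c2ccccc2)c1F`: 99.9%
Compound 2, `CCOc1cc(C)cc(C(=O)NNS(=O)(=O)c2ccccc2F)c1`: 99.6%

Both compounds were tested in an ADME assay on a cell-free system (plasma, Mus musculus) for protein binding, read by LC-MS, using ultracentrifugation, with a stated time of 4.2 h, tested at 1000 ng/mL. In this assay compound 1 gives 99.9%, so almost all of it sits on plasma protein. Compound 2 gives 99.6%; of the two, compound 2 leaves the larger share free, and the gap to compound 1 lies beyond the usual scatter.

Compound 3, `Cc1cc(OC(C)C)cc(C(=O)NNS(=O)(=O)c2ccccc2F)c1`, is not yet measured. It differs from compound 2 in one place: methyl in place of hydrogen on a saturated chain carbon bound to an oxygen on an aromatic ring and a saturated chain carbon. Within the data shown here, no pair of measured compounds shows this kind of change, so no measured step can guide the expectation directly. With one carbon added and nothing else altered, the step a 1.3-fold lower unbound fraction from compound 2 to compound 3 (0.12 log units; within the scatter) is expected to be small, toward slightly more binding, and not beyond the scatter. For compound 3 the estimated value is 99.7%, with a range from 99.3% to 99.9%.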

Compound 3, plasma protein binding in the Mus musculus assay: 98.9%
Compound 3: the middle estimate sits 3.7-fold (0.56 log units) (unbound fraction) below what was measured; measured number below the stated range.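

Changing ethoxy to isopropoxy adds a single methyl on the saturated chain carbon bound to the oxygen, and in the Mus musculus assay this gives a 2.8-fold higher unbound fraction from compound 2 to compound 3 (0.44 log units; beyond the scatter). So at this place, even one added carbon can shift the free share by more than the usual scatter, and the shift runs toward more free compound rather than less. In a physicochemical assay for solubility, read by nephelometry, measured as kinetic solubility, at pH 2 (on this read-out higher numbers stand for higher solubility and lower numbers for lower solubility), compound 2 gives 12.5 ug/mL and compound 3 gives 12.5 ug/mL, so the same change leaves that read-out unmoved, and nothing available explains the shift in binding.

This is one step at one place, so it sets no trend. Going by these compounds, whether a tert-butoxy group, a longer chain such as propoxy, or a methoxy group would continue or reverse the shift remains open.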